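Swapping the Phenyl Tail for an Ester

The source may hold more compounds than are shown below. What is called first, only, known or untested is meant among the compounds shown, and "the series" means these compounds.

Of the compounds shown here, three have been measured in an assay on HEK293 cells for displacement of a labelled ligand from prostaglandin D2 receptor 2 (Homo sapiens); a higher number here means a weaker inhibitor, a lower number a stronger inhibitor. Compound 1 `O=C(O)Cn1c(SCCCOc2ccccc2)nc2ccccc21` gives 786 nM. Compound 2 `O=C(O)Cn1c(SCCCc2ccccc2)nc2ccccc21` gives 475 nM. Compound 3 `O=C(O)Cn1c(SCCc2ccccc2)nc2ccccc21` gives 881 nM.

Compound 3 stands at the highest of these three numbers, yet neither step to it goes beyond the usual scatter: a 1.1-fold higher number from compound 1 to compound 3 (0.05 log units; within the scatter) and a 1.9-fold higher number from compound 2 to compound 3 (0.27 log units; within the scatter). The remaining step, a 1.7-fold lower number from compound 1 to compound 2 (0.22 log units; within the scatter), is likewise within the scatter. Compound 4 `CCOC(=O)CCSc1nc2ccccc2n1CC(=O)O` differs from compound 3 in one place: ethoxycarbonyl in place of phenyl on a saturated chain carbon, two bonds along the chain from a sulfur. Within the data shown here, no measured step tests a change of this kind; all three steps exchange one aromatic-bearing tail for another and leave the number essentially where it was. Among the measured compounds shown here, every measured compound keeps an aromatic ring in the tail, and compound 4 is the first to lose it, so the measured steps give no firm guide and the uncertainty is wide. On this basis compound 4 is expected to give 2000 nM in this assay, with an estimated range from 600 nM to 7000 nM. The expected step is a 2.3-fold higher number from compound 3 to compound 4 (0.36 log units; beyond the scatter), a tentative shift toward a weaker inhibitor.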

Compound 4, half-maximal inhibitory concentration: 11400 nM
Compound 4: the middle estimate sits 5.7-fold (0.76 log units) below what was measured, and the stated range ends below it.
By their numbers in this assay, from the lowest: compounds 2, 1 and 3 (each within the scatter of the next); then compound 4.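

At this position, swapping one aromatic-bearing tail for another left the number within the scatter, but ethoxycarbonyl gives a 13-fold higher number from compound 3 to compound 4 (1.11 log units; beyond the scatter) and a 24-fold higher number from compound 2 to compound 4 (1.38 log units; beyond the scatter) and a 15-fold higher number from compound 1 to compound 4 (1.16 log units; beyond the scatter) in this assay with all three steps large. Among these compounds, the tail on this chain therefore matters after all, and compound 4, the only one without an aromatic ring, is a weaker inhibitor than each of the other three. Nothing available bears on the reason for this large change.

Compound 4 carries the only ring-free tail shown, so it remains open whether the loss follows from removing the phenyl ring or from bringing in the ester. A cyclohexyl ring, a plain butyl chain or a carboxylic acid on the same chain could help tell these apart.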